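The compounds below may be only part of what the source reports. "The series", "measured", "known", "first", "only" and "open" are said of these compounds alone.

Compound 2 `Cc1cccc(-c2cn3ccnc3c(-c3ccc4ncn(Cc5ccccc5)c4c3)n2)c1` stands lowest of the two measured numbers in a functional assay on A549 cells (Homo sapiens) for inhibition, read by sulforhodamine B assay, with a stated time of 48 h, tested at 10 uM (on this read-out higher numbers stand for more inhibition at the one concentration tested (going by the name of the read-out) and lower numbers for less inhibition), where compound 2 gives 14.9%. Its nearest neighbour is compound 1 `CCc1ccc(-c2cn3ccnc3c(-c3ccc4ncn(Cc5ccccc5)c4c3)n2)cc1`, which in this assay gives 45.4%. For the measured compounds named here, the only measured step, a number 30.5 percentage points lower from compound 1 to compound 2 (beyond the scatter), is the sole guide available. Compound 3 `c1ccc(Cn2cnc3ccc(-c4nc(-c5cccc6ccccc56)cn5ccnc45)cc32)cc1` differs from compound 2 by naphthalen-1-yl in place of 3-methylphenyl on an aromatic carbon. Going by the values given here, no measured pair exchanges a 3-methylphenyl for a naphthalen-1-yl, so the measured step bears on the case only in showing that a change of the aryl group on this carbon can move the read-out by a large amount. Against that background a step upward is expected for a number 20.1 percentage points higher from compound 2 to compound 3 (beyond the scatter), though its size is uncertain, since a naphthalen-1-yl is untested in this series. Compound 3 is therefore estimated at 35% in this assay, with a range from 10% to 65%.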

Compound 3, a percentage reported as inhibition, at one concentration (the size of the read-out at that concentration, not a potency): 7.31%
For compound 3 the middle estimate is 27.7 percentage points above the measured one; the measured number lies below the stated range.
By their numbers in this assay, from the lowest: compounds 3 and 2 (each within the scatter of the next); then compound 1.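

In this assay, putting naphthalen-1-yl in place of 3-methylphenyl on this aromatic carbon gives a number 7.6 percentage points lower from compound 2 to compound 3 (within the scatter) and so does not separate these two groups. Putting it in place of 4-ethylphenyl gives a number 38.1 percentage points lower from compound 1 to compound 3 (beyond the scatter) and shows that, of the three aryl groups here, 4-ethylphenyl alone stands apart, with the two others together well under it. No measured evidence accounts for this pattern.

Going by these compounds, it stays open whether the higher number of compound 1 goes with the ethyl group, with its place on the phenyl ring, or with both, and how an unsubstituted phenyl, a 4-methylphenyl or a 3-ethylphenyl would read. Also open, on these data alone, is how a longer chain, an amine or a carboxylic acid on that ring would read.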